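Swapping Fluorine for Chlorine on a Urea-Linked Arene

A few compounds are considered here, and "the series" means these few. Any claim that something is new, unique, unknown or untested is made for them only; others in the source may bear on it.

Two measured compounds share one core and differ from each other in two places. Compound 1 `CN(C)CCNc1nc(-c2ccc(NC(=O)Nc3ccc(Cl)cc3)cc2)nc2c(Cl)c(Cl)sc12` carries a chloro group on a six-membered aromatic ring of carbon only; in a functional assay on MDA-MB-231 cells (Homo sapiens) for cytotoxicity, read by MTT assay, with a stated time of 72 h (a higher number here means a weaker inhibitor, a lower number a stronger inhibitor), compound 1 gives 870 nM. Compound 2 `CCN(CC)CCCNc1nc(-c2ccc(NC(=O)Nc3ccc(F)cc3)cc2)nc2c(Cl)c(Cl)sc12` carries a fluoro group there and a different amine chain; in this assay compound 2 gives 1630 nM. Compound 2 has the higher of these two numbers, but its gap to compound 1 lies within the scatter, so the two cannot be told apart.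

Compound 3 `CCN(CC)CCCNc1nc(-c2ccc(NC(=O)Nc3ccc(Cl)cc3)cc2)nc2c(Cl)c(Cl)sc12` keeps the amine chain of compound 2 and differs from it in one way: chloro in place of fluoro on an aromatic carbon, para to a large group. Within the data shown here, no pair of measured compounds differs by this change alone, so no measured step for it exists; the only guide is that compound 1 and compound 2, which differ here and in the chain, sit within the scatter of each other. Compound 3 is therefore expected to give 1100 nM, with a range from 450 nM to 2700 nM. The expected step of a 1.5-fold lower number from compound 2 to compound 3 (0.17 log units; within the scatter) is small and within the scatter.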

Compound 3, half-maximal inhibitory concentration: 660 nM
Estimate against measurement, compound 3: 1.7-fold (0.22 log units) above; the range from low to high includes it.
By their numbers in this assay, from the lowest: compounds 3, 1 and 2 (each within the scatter of the next, the first and the last beyond it).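

In this assay, among these compounds, the change from 4-fluorophenyl to 4-chlorophenyl, with the amine chain held fixed, gives a 2.5-fold lower number from compound 2 to compound 3 (0.39 log units; beyond the scatter) and so isolates this halogen swap for the first time; the step is modest, but it shows that the result at this place on the ring can depend on which halogen sits there. The chain change, (diethylamino)methyl in place of dimethylamino with the 4-chlorophenyl group held fixed, gives a 1.3-fold lower number from compound 1 to compound 3 (0.12 log units; within the scatter) and so cannot be told from no change in this pair. No measurement of any property of these groups accompanies these results, and the reason for the halogen step stays unknown.

This single pair leaves open whether a bromo, methoxy or trifluoromethyl group at this place, or plain hydrogen, would fall near chloro or near fluoro, or outside both. It also leaves open whether the same halogen swap gives a similar step on the shorter dimethylamino chain, and whether a morpholine at the end of the chain would keep the values of these two amines.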